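Swapping Methyl for Fluoro on Compound 2

This account rests on a few compounds, and the source may have more. Where it says the series, first, only, none or still open, it means among the compounds named here.

Compound 1 `CN(C(=O)/C=C/c1ccc(C(C)(C)C)cc1)c1ccc2c(c1)OCCO2`: in a functional assay on CHO cells for inhibition of transient receptor potential cation channel subfamily V member 1 (Homo sapiens) (a higher number here means a weaker inhibitor, a lower number a stronger inhibitor), compound 1 gives > 4000 nM, which is a limit of the assay rather than a number.
Compound 2 `Cc1ccc(/C=C/C(=O)Nc2ccc3c(c2)OCCO3)cc1`: compound 2 gives 210 nM in this assay.

For the measured compounds named here, compound 2 thus holds the only true number in this assay. Compound 1 sits at the limit of > 4000 nM in this assay, at which 1 of the 2 values shown sits, so the two cannot be compared beyond saying that compound 1 reaches no measurable value.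

Compound 3 `O=C(/C=C/c1ccc(F)cc1)Nc1ccc2c(c1)OCCO2` differs from compound 2 in one place: fluoro in place of methyl on an aromatic carbon. Both keep the amide hydrogen and the shared core of compound 2. Going by the values given here, with no measured pair of this kind to lean on, the step from compound 2 to compound 3 in this assay is expected to be modest, leaning toward a weaker inhibitor, and it may not exceed the usual scatter; the expected step is a 1.9-fold higher number from compound 2 to compound 3 (0.28 log units; within the scatter). Compound 3 is therefore estimated at 400 nM in this assay, within a range from 120 nM to 1500 nM.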

Compound 3, half-maximal inhibitory concentration: 1000 nM
The estimate for compound 3 lay 2.5-fold (0.40 log units) below the measured number, and the stated range covers the measured number.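

Compounds 2 and 3 are the only pair shown that differs in one place, so they give the first direct reading of this position in this assay. With the amide hydrogen and the shared core kept, fluoro in place of methyl gives a 4.8-fold higher number from compound 2 to compound 3 (0.68 log units; beyond the scatter), so exchanging one heavy atom on an aromatic carbon, para to a large group, is enough to give a weaker inhibitor. Nothing shown here accounts for the size or direction of this step.

Going by these compounds, whether chloro, methoxy or an amine at this position would give a stronger or weaker inhibitor than methyl or fluoro stays open. Compound 1 differs from compound 2 in more than one place and cannot settle what the amide hydrogen contributes.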